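Aryl variation at the imidazopyrazine position and cell inhibition

The source may report more compounds than this note shows. Statements on the series, on what has been measured and on what is new or still open speak of the compounds shown alone.

Measured so far:
compound 1 `Brc1cn2ccnc2c(-c2ccc3ncn(C4CCCCC4)c3c2)n1`: 22.5%
compound 2 `c1ccc2c(-c3cn4ccnc4c(-c4ccc5ncn(C6CCCCC6)c5c4)n3)cccc2c1`: 9.45%

In a functional assay on NCI-H226 cells (Homo sapiens) for inhibition, read by sulforhodamine B assay, with a stated time of 48 h, tested at 10 uM (a lower number here means less inhibition, a higher number more inhibition at the concentration tested (going by the name of the read-out)), compound 2 gives the lower of the two numbers; compound 1 stands above it by a number 13.1 percentage points lower from compound 1 to compound 2 (beyond the scatter). Compound 3 `Clc1ccc(-c2cn3ccnc3c(-c3ccc4ncn(C5CCCCC5)c4c3)n2)cc1` differs from compound 2 in one place: 4-chlorophenyl in place of naphthalen-1-yl on an aromatic carbon. Going by the values given here, no measured step swaps naphthalen-1-yl for 4-chlorophenyl; the only step known, from bromo to naphthalen-1-yl, was modest. A small move back toward compound 1 is therefore expected, of about a number 5.6 percentage points higher from compound 2 to compound 3 (within the scatter). For compound 3 the estimate in this assay is 15%, with a range from 0% to 35%.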

Compound 3, a percentage reported as inhibition, at one concentration (the size of the read-out at that concentration, not a potency): 19.4%
Estimate against measurement, compound 3: 4.4 percentage points below, within the range that was stated.
By their numbers in this assay, from the lowest: compounds 2, 3 and 1 (each within the scatter of the next, the first and the last beyond it).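

In this assay the 4-chlorophenyl group gives a number 10 percentage points higher from compound 2 to compound 3 (within the scatter) and also a number 3.1 percentage points lower from compound 1 to compound 3 (within the scatter) so compound 3 cannot be separated from either compound 2 or compound 1. The drop seen with naphthalen-1-yl in compound 2 is therefore not shown to extend to a single aromatic ring at this position, and only that pair of compounds lies beyond the scatter. Nothing available accounts for these numbers. As far as these compounds go, whether an amine or a carboxylic acid on the phenyl ring would separate from compound 1 remains open.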